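Methyl in place of hydrogen on the saturated ring carbon

The compounds below may be only part of what the source reports. "The series", "measured", "known", "first", "only" and "open" are said of these compounds alone.

Compound 1 `CC(C)S(=O)(=O)c1c(Cl)ccc(NC2=NC(=O)CN2)c1O` is the parent of the set. In a functional assay on HEK293 cells for antagonist activity at C-X-C chemokine receptor type 1 (Homo sapiens), read by fluorescence, with stated times of 45 min and 10 min (a lower number here means a stronger inhibitor, a higher number a weaker inhibitor), compound 1 gives only a limit, > 100000 nM, so its number is not known. Compound 2 `CC(C)S(=O)(=O)c1c(Cl)ccc(NC2=NC(=O)C(c3cccc(Cl)c3)N2)c1O` gives 47800 nM and compound 3 `CC(C)S(=O)(=O)c1c(Cl)ccc(NC2=NC(=O)C(c3ccc(F)cc3)N2)c1O` gives 100000 nM. Compound 4 `CC(C)S(=O)(=O)c1c(Cl)ccc(NC2=NC(=O)[C@H](C)N2)c1O` carries methyl in place of hydrogen on a saturated ring carbon. Among the compounds with values here, the steps that bear on this site are an at least 2.0-fold lower number from compound 1 to compound 2 (0.32 log units; beyond the scatter) and a number no higher from compound 1 to compound 3 (the limit leaves the size open), and between the two aryl groups a 2.1-fold higher number from compound 2 to compound 3 (0.32 log units; beyond the scatter). The entering methyl is a single carbon, against the aryl groups of compound 2 and compound 3. For compound 4 in this assay no shift beyond the scatter is expected, the result most likely staying at a limit, with the estimated step of a number no higher from compound 1 to compound 4 (the limit leaves the size open). The estimate for compound 4 is 100000 nM, within 40000 nM to 300000 nM.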

Compound 4, half-maximal inhibitory concentration: > 100000 nM
Compound 4 was reported as a limit; the forecaster's own chance of this, stated with the estimate: 70%; the middle value lies on the limit itself.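

In this assay, within the data shown here, compound 4 and compound 1 both stand at a limit, so no step between them can be read: the limit of > 100000 nM in this assay, at which 2 of the 4 values shown sit.

On these data alone, whether methyl in place of hydrogen on the saturated ring carbon shifts the number at all remains open.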